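Aryl amide variation on the shared core

The compounds below may be only part of what the source reports. "The series", "measured", "known", "first", "only" and "open" are said of these compounds alone.

Compound 1 `N#Cc1cccc(C(=O)NCN2CCC(c3cccc[n+]3[O-])CC2)c1` gives 840 nM in a functional assay on HEK293 cells for agonist activity at D(4) dopamine receptor (Homo sapiens), read by FLIPR (on this read-out lower numbers stand for an effect already at smaller amounts and higher numbers for an effect only at larger amounts of compound), the highest of the three numbers measured. Compound 3 `CCOc1cccc(C(=O)NCN2CCC(c3cccc[n+]3[O-])CC2)c1` gives 324 nM and compound 2 `O=C(NCN1CCC(c2cccc[n+]2[O-])CC1)c1ccc2ccccc2c1` gives 115 nM, so compound 1 sits furthest from compound 2. Compound 4 `O=C(NCN1CCC(c2cccc[n+]2[O-])CC1)c1ccc(F)c(Cl)c1` differs from compound 1 by 3-chloro-4-fluorophenyl in place of 3-cyanophenyl on a carbonyl carbon. Going by the values given here, the one measured step that bears on this change is a 2.6-fold lower number from compound 1 to compound 3 (0.41 log units; beyond the scatter), a modest step from exchanging a single substituent on an aromatic carbon. Compound 2 further shows that a different aromatic group on the carbonyl carbon gives a lower number still. A modest drop is therefore expected; the estimated step is a 2.8-fold lower number from compound 1 to compound 4 (0.45 log units; beyond the scatter). Compound 4 is expected to give 300 nM, with a range of 110 nM to 800 nM.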

Compound 4, half-maximal effective concentration: 63 nM
Beside the measured number, compound 4's estimate is 4.8-fold (0.68 log units) above it, and the stated range ends above it.
By their numbers in this assay, from the lowest: compounds 4 and 2 (each within the scatter of the next); then compound 3; then compound 1.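

In this assay, the exchange of 3-cyanophenyl for 3-chloro-4-fluorophenyl on a carbonyl carbon gives a 13-fold lower number from compound 1 to compound 4 (1.12 log units; beyond the scatter), a large step, whereas a 2.6-fold lower number from compound 1 to compound 3 (0.41 log units; beyond the scatter) was modest. This position therefore allows a much lower number with a phenyl group carrying chlorine and fluorine, and compound 4 and compound 2 lie within the scatter of each other. No measured evidence accounts for this step.

The compounds shown do not separate the contribution of chlorine from that of fluorine. On these data alone, how a phenyl group carrying only one of these halogens, an amine or a carboxylic acid would read remains open.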